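Hydroxy for Trifluoromethyl on a Weakly Cytotoxic Amide

A few compounds are considered here, and "the series" means these few. Any claim that something is new, unique, unknown or untested is made for them only; others in the source may bear on it.

Measured compounds:
compound 1, `O=C(Nc1ccccc1C(F)(F)F)C1CCc2ccccc2N1`, 56800 nM
compound 2, `O=C(Nc1ccccc1C(F)(F)F)C1CCc2ccccc2N1C(=O)c1ccc(Cl)cc1`, 307 nM

In a functional assay on NCI-H23 cells (Homo sapiens) for cytotoxicity, read by sulforhodamine B assay, with a stated time of 72 h (on this read-out higher numbers stand for weaker inhibition of growth and lower numbers for stronger inhibition of growth), compound 1 gives 56800 nM, the highest of the two numbers recorded, and therefore the weaker of the two on this read-out. Its nearest neighbour is compound 2, which differs only at the ring nitrogen of the shared core and gives 307 nM; this gives a 190-fold lower number from compound 1 to compound 2 (2.27 log units; beyond the scatter).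

Compound 3, `O=C(Nc1ccccc1O)C1CCc2ccccc2N1`, has not been measured. It differs from compound 1 by hydroxy in place of trifluoromethyl on an aromatic carbon. For the measured compounds named here, the only measured step, from compound 1 to compound 2, concerns a different place, the ring nitrogen, and tells nothing about the aromatic ring of the amide substituent. Going by the values given here, no measured pair therefore bears directly on the change from compound 1 to compound 3, and the expectation for compound 3 rests on compound 1 alone.

With no guide from the data, compound 3 is expected to stay near compound 1, the step of a 1.1-fold higher number from compound 1 to compound 3 (0.02 log units; within the scatter) expected to lie within the scatter. Compound 3 is thus estimated at 60000 nM, with a range from 15000 nM to 200000 nM.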

Compound 3, concentration for 50% growth inhibition: 2230 nM
Compound 3: the middle estimate sits 27-fold (1.43 log units) above what was measured; measured number below the stated range.
By their numbers in this assay, from the lowest: compound 2; then compound 3; then compound 1.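

The aromatic ring of the amide substituent proves to be a place where a single change counts in this assay: hydroxy in place of trifluoromethyl on this aromatic carbon, ortho to a large group, gives a 25-fold lower number from compound 1 to compound 3 (1.41 log units; beyond the scatter). For the compounds shown here, until now, the only measured change lay at the ring nitrogen, whereas this step shows that a second place on the shared core also moves growth inhibition by an amount well beyond the scatter, with the ring nitrogen left unchanged. Nothing measured here accounts for the size of this step or says what lies behind it.

The step cannot separate the loss of trifluoromethyl from the entry of hydroxy, and a compound carrying methoxy, an amine or only hydrogen on this aromatic carbon would help to tell these two apart. As far as these compounds go, it also remains open whether hydroxy would bring a similar change on compound 2, which carries (4-chlorophenyl)carbonyl on the ring nitrogen, so whether the two changes add together is unknown.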